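Vero cytotoxicity notes on the shared core series

The compounds below may be only part of what the source reports. "The series", "measured", "known", "first", "only" and "open" are said of these compounds alone.

Compound 2 `COc1ccc2[nH]c(C(=O)N3CC(=O)N(Cc4ccccc4)[C@@H](COc4ccc(F)cc4)C3)cc2c1` is the reference point. Within the data shown here, in an ADME assay on Vero cells (Chlorocebus sabaeus) for cytotoxicity, with a stated time of 7 days (on this read-out higher numbers stand for lower toxicity in this test and lower numbers for higher toxicity in this test), compound 2 gives 33200 nM, the only number recorded in this read-out among the compounds measured so far. Compound 1 `COc1ccc2[nH]c(C(=O)N3CC(=O)N(Cc4ccccc4)[C@@H](CCc4ccccc4)C3)cc2c1` in this assay gives > 30000 nM, which is a limit of the assay and not a number. Among the measured compounds shown here, the one recorded step, a step that the limit leaves unreadable from compound 1 to compound 2, therefore has no readable size, because the limit of > 30000 nM in this assay, at which 1 of the 2 values shown sits, sets one end of it.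

Compound 3 `COc1ccc2[nH]c(C(=O)N3CC(=O)N(Cc4ccccc4)[C@@H](CN4CCc5ccccc5C4)C3)cc2c1` is not yet measured in this assay. It differs from compound 2 in one place: 1,2,3,4-tetrahydroisoquinolin-2-yl in place of 4-fluorophenoxy on a saturated chain carbon bound to a saturated ring carbon. For the measured compounds named here, no measured step speaks to this change with a readable size; the only step recorded, a step that the limit leaves unreadable from compound 1 to compound 2, carries none. Going by the values given here, with compound 2 sitting at the single number in hand, the step from compound 2 to compound 3 in this assay is expected to be a 1.1-fold lower number from compound 2 to compound 3 (0.04 log units; within the scatter), no shift beyond the usual scatter in either direction, and a limit rather than a number remains quite possible. Compound 3 is estimated at 30000 nM in this assay, within a range from 12000 nM to 75000 nM.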

Compound 3, half-maximal cytotoxic concentration: 51800 nM
Beside the measured number, compound 3's estimate is 1.7-fold (0.24 log units) below it; measured number inside the range.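

Working note on the chain carbon bound to the saturated ring carbon: 1,2,3,4-tetrahydroisoquinolin-2-yl in place of 4-fluorophenoxy gives a 1.6-fold higher number from compound 2 to compound 3 (0.19 log units; within the scatter) in this assay, the first step at this place with a readable size. The change removes the fluorine and the oxygen link and brings in a non-aromatic ring with a hetero atom, yet compound 3 remains within the scatter of compound 2, so these two groups cannot be told apart in this read-out. Compound 1 gives > 30000 nM, which is a limit of the assay and not a number, and the steps that start from compound 1 cannot be read: the limit of > 30000 nM in this assay, at which 1 of the 3 values shown sits.

Going by these compounds, all three groups at this place carry a six-membered aromatic ring of carbon only, so the reading in this assay for a group without such a ring, such as a carboxylic acid or an open-chain amine, stays open. Also open, on these data alone, is whether any change at this place can move the number beyond the usual scatter, and whether the benzyl group or the methoxy group of the shared core has any bearing on it.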